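Swapping the dichlorophenyl amide for a branched alkyl amide

The compounds below may be only part of what the source reports. "The series", "measured", "known", "first", "only" and "open" are said of these compounds alone.

Measured compounds:
compound 1 `O=C(Nc1ccc2nc(NC(=O)C3CCCCC3)sc2c1)c1ccc(Cl)cc1Cl` gives > 4 ug/mL in a functional assay on WI-38 VA13 cells (Homo sapiens) for cytotoxicity (on this read-out higher numbers stand for an effect only at larger amounts of compound and lower numbers for an effect already at smaller amounts), which is a limit of this assay.
compound 2 `O=C(Nc1ccc2nc(NC(=O)C3CCCCC3)sc2c1)c1c(Cl)cccc1Cl` gives 0.015 ug/mL in this assay.

Compound 2 holds the only actual number shown in this assay; the other result, that of compound 1, sits at the limit of > 4 ug/mL in this assay, at which 1 of the 2 values shown sits. For the measured compounds named here, the one measured step, an at least 260-fold lower number from compound 1 to compound 2 (2.42 log units; beyond the scatter), shows that moving the chlorines on the phenyl group changes the read-out greatly. Compound 3 `CCCC(C)C(=O)Nc1ccc2nc(NC(=O)C3CCCCC3)sc2c1` differs from compound 2 by 1-methylbutyl in place of 2,6-dichlorophenyl on a carbonyl carbon. Going by the values given here, no measured step removes the aromatic ring altogether, so the step from compound 1 to compound 2 bears on it only indirectly, by showing how sensitive this assay is to what sits on the carbonyl carbon. A large loss is therefore expected, with a real chance that compound 3 reaches only the limit. Compound 3 is estimated at 1.5 ug/mL, between 0.1 ug/mL and 10 ug/mL, a step of a 100-fold higher number from compound 2 to compound 3 (2.00 log units; beyond the scatter).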

Compound 3, half-maximal effective concentration: 0.14 ug/mL
Estimate against measurement, compound 3: 11-fold (1.03 log units) above; the range from low to high includes it.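

Replacing the ring with a chain in this assay gives a 9.3-fold higher number from compound 2 to compound 3 (0.97 log units; beyond the scatter), so 1-methylbutyl on this carbonyl carbon still keeps the number low, though 2,6-dichlorophenyl gives the lower of the two values. Set against 2,4-dichlorophenyl, the same chain gives an at least 28-fold lower number from compound 1 to compound 3 (1.45 log units; beyond the scatter), which places one dichlorophenyl group on either side of 1-methylbutyl and shows that an aromatic ring alone does not decide the read-out here. This second step gives only a bound on the size of the change because the value of compound 1 is a limit: the limit of > 4 ug/mL in this assay, at which 1 of the 3 values shown sits.

The compounds shown leave open how an unsubstituted phenyl, a longer chain or a chain carrying an amine would read out at this position. They also leave open what happens when the cyclohexyl group at the other amide, the same in all three compounds, is replaced.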